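The compounds below may be only part of what the source reports. "The series", "measured", "known", "first", "only" and "open" are said of these compounds alone.

Among the measured compounds shown here, only two compounds on the shared core have readings in an ADME assay on THP-1 cells (Homo sapiens) for cytotoxicity, read by flow cytometry and propidium iodide staining, with a stated time of 72 h; a lower number here means a stronger inhibitor, a higher number a weaker inhibitor. Compound 1 `COc1ccccc1-c1oc2ccc(NC(C)=O)cc2c(=O)c1O` reads > 125000 nM, which is a limit of the assay and not a number. For the measured compounds named here, compound 2 `Nc1ccc2oc(-c3ccccc3)c(O)c(=O)c2c1` gives 27000 nM, the only true number so far.

Compound 3 `COc1ccccc1-c1oc2ccc(N)cc2c(=O)c1O` departs from compound 2 at one place: methoxy in place of hydrogen on an aromatic carbon, ortho to a large group. Going by the values given here, no measured step isolates this change, so the expectation rests on thin ground. Compound 1 also carries the methoxy, but it differs from compound 2 in a second place as well. Compound 1 reads > 125000 nM, a limit of the assay, and therefore gives only a loose hint. That hint points toward weaker inhibition. The expected change is a 2.2-fold higher number from compound 2 to compound 3 (0.35 log units; beyond the scatter), an estimated step close to the edge of the scatter. Compound 3 is estimated at 60000 nM, with an expected range from 20000 nM to 125000 nM.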

Compound 3, half-maximal inhibitory concentration: 102000 nM
Compound 3: middle estimate off by 1.7-fold (0.23 log units), on the low side, and the stated range covers the measured number.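

In this assay, the methoxy in place of hydrogen on an aromatic carbon, ortho to a large group, now has a measured step of its own: a 3.8-fold higher number from compound 2 to compound 3 (0.58 log units; beyond the scatter), so in this one pair the change alone goes with a weaker reading, beyond the scatter. Compound 1 reads > 125000 nM, which is a limit of the assay and not a number. Compound 3 also gives the first reading of hydrogen in place of acetyl on a nitrogen on an aromatic ring, an at least 1.2-fold lower number from compound 1 to compound 3 (0.08 log units; that floor lies within the scatter), and the true size of this change stays unknown because that step starts from a limit: the limit of > 125000 nM in this assay, at which 1 of the 3 values shown sits.

The compounds shown leave open whether this step belongs to methoxy itself or would also appear with another group at this place, such as fluorine, hydroxyl or the longer ethoxy. Going by these compounds, it is also open whether the step would hold with a group other than the amine or the acetyl on the nitrogen, such as a methyl or a longer acyl chain.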